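This account rests on a few compounds, and the source may have more. Where it says the series, first, only, none or still open, it means among the compounds named here.

Of the compounds shown here, three built on one shared core have been measured in a physicochemical assay for lipophilicity, using the shake flask method; on this read-out higher numbers stand for higher lipophilicity and lower numbers for lower lipophilicity. Compound 1 `Nc1ncnc(Oc2ccc(NC(=O)C3(C(=O)Nc4ccc(F)cc4)CC3)cc2F)c1/C=N/O` gives 2.62. Compound 2 `Nc1ncnc(Oc2ccc(NC(=O)C3(C(=O)Nc4ccc(F)cc4)CC3)cc2F)c1/C=N/OCCO` gives 2.37, and compound 3 `CNc1ncnc(Oc2ccc(NC(=O)C3(C(=O)Nc4ccc(F)cc4)CC3)cc2F)c1/C=N/OC` gives 3.52. Compound 2 thus holds the lowest of the three numbers; its nearest neighbour is compound 1, separated by a number 0.25 log units lower from compound 1 to compound 2 (within the scatter), a step within the scatter, while compound 3 lies furthest from it. Among the measured compounds shown here, the only step that moves the number beyond the scatter is a number 0.90 log units higher from compound 1 to compound 3 (beyond the scatter).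

Compound 4 `CC(O)CO/N=C/c1c(N)ncnc1Oc1ccc(NC(=O)C2(C(=O)Nc3ccc(F)cc3)CC2)cc1F` differs from compound 2 by methyl in place of hydrogen on a saturated chain carbon bound to an oxygen on a saturated carbon and a saturated chain carbon. For the measured compounds named here, the step that bears on this change is the one from compound 1 to compound 2, which also grew the chain on that oxygen and stayed within the scatter; the step from compound 1 to compound 3 touches a different part of the molecule and says little here. Going by the values given here, a step no larger than the scatter, tilted slightly upward, is expected for compound 4 in this assay because the closest precedent a number 0.25 log units lower from compound 1 to compound 2 (within the scatter) itself stayed within the scatter, giving an expected a number 0.23 log units higher from compound 2 to compound 4 (within the scatter). Compound 4 is therefore estimated at 2.6, within a range from 2.3 to 3.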

Compound 4, partition coefficient: 2.75
Beside the measured number, compound 4's estimate is 0.15 log units below it, within the range that was stated.
By their numbers in this assay, from the lowest: compounds 2, 1 and 4 (each within the scatter of the next, the first and the last beyond it); then compound 3.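

In this assay, the single methyl that turns 2-hydroxyethyl into 2-hydroxypropyl gives a number 0.38 log units higher from compound 2 to compound 4 (beyond the scatter), so a change this small at this saturated chain carbon can move the read-out past the usual scatter. Yet when the whole 2-hydroxypropyl group is compared with plain hydrogen on the oxygen, the result is a number 0.13 log units higher from compound 1 to compound 4 (within the scatter), which means this chain leaves the number where the bare hydrogen had it, even though the methyl step alone is a real one. Nothing measured here explains the shift.

The compounds shown leave open how the number would respond to a longer chain, such as 3-hydroxypropyl, on the same oxygen. They also leave open what an amine or a carboxylic acid in place of the chain's hydroxyl would do.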